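Swapping cyano for trifluoromethyl on a second core

This account rests on a few compounds, and the source may have more. Where it says the series, first, only, none or still open, it means among the compounds named here.

Compound 1 `N#Cc1ccc(NC(=O)c2ccc(Cl)cc2O)cc1` and compound 2 `O=C(Nc1ccc(C(F)(F)F)cc1)c1ccc(Cl)cc1O` share one core and differ by trifluoromethyl in place of cyano on an aromatic carbon. In a functional assay on KG-1 cells (Homo sapiens) for cytotoxicity, read by luminescence and CellTiter-Glo, with a stated time of 3 days (on this read-out higher numbers stand for weaker inhibition and lower numbers for stronger inhibition), compound 1 gives 1920 nM and compound 2 gives 580 nM. That change made a 3.3-fold lower number from compound 1 to compound 2 (0.52 log units; beyond the scatter). Compound 3 `N#Cc1ccc(NC(=O)c2ccc3cccnc3c2O)cc1` carries another core; the difference between the two cores is not broken down here. In this assay compound 3 gives 2320 nM, a number close to that of compound 1. Compound 4 `O=C(Nc1ccc(C(F)(F)F)cc1)c1ccc2cccnc2c1O` has not been measured; it differs from compound 3 by trifluoromethyl in place of cyano on an aromatic carbon, the same change as that between compound 1 and compound 2. For the measured compounds named here, since the one measured instance of this change gave a 3.3-fold lower number from compound 1 to compound 2 (0.52 log units; beyond the scatter), a step of comparable size, a 3.3-fold lower number from compound 3 to compound 4 (0.52 log units; beyond the scatter), is expected, resting on that single pair alone. On this basis compound 4 is estimated at 700 nM in this assay, with a likely range from 300 nM to 1700 nM.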

Compound 4, half-maximal inhibitory concentration: 3510 nM
Compound 4: the middle estimate sits 5.0-fold (0.70 log units) below what was measured, and the stated range ends below it.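

In this assay, swapping cyano for trifluoromethyl gave a 1.5-fold higher number from compound 3 to compound 4 (0.18 log units; within the scatter), so on the core of compound 3 the swap made no change that stands clear of the scatter. Set side by side, the two steps differ: the same change on two cores in this assay, a 3.3-fold lower number (0.52 log units; beyond the scatter) from compound 1 to compound 2 and a 1.5-fold higher number (0.18 log units; within the scatter) from compound 3 to compound 4, 5.0-fold (0.70 log units) apart, beyond the scatter of two such steps. This shows that a drop in the number seen on one core cannot be assumed on another in this series, but it does not show why, and two pairs give no rule for other cores.

The compounds shown carry only cyano or trifluoromethyl at this place, so it stays open how an amine or a carboxylic acid there would behave on either core. On these data alone, it also stays open which of the two pairs a third core would resemble.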